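A few compounds are considered here, and "the series" means these few. Any claim that something is new, unique, unknown or untested is made for them only; others in the source may bear on it.

Compound 1 `CCO[C@]1(c2ccc(OCc3c(-c4c(Cl)cccc4Cl)noc3C3CC3)cc2Cl)C[C@H](c2cccc(C(=O)O)c2)C1` gives 220 nM in an assay on HEK293 cells for agonist activity at Bile acid receptor (Homo sapiens); on this read-out lower numbers stand for an effect already at smaller amounts and higher numbers for an effect only at larger amounts of compound.
Compound 2 `CS(=O)(=O)NC(=O)c1ccc(C2CC2c2ccc(OCc3c(-c4c(Cl)cccc4Cl)noc3C3CC3)cc2Cl)cc1` gives 44 nM in this assay.
Compound 3 `O=C(O)c1cccc(C2CC2c2ccc(OCc3c(-c4c(Cl)cccc4Cl)noc3C3CC3)cc2Cl)c1` gives 34 nM in this assay.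

Compound 3 shows the lowest number of the three, but compound 2 sits within the usual scatter of it; only compound 1 lies clearly beyond, with a markedly higher number. Compound 4 `CC(C)n1nc(C(=O)O)cc1C1CC1c1ccc(OCc2c(-c3c(Cl)cccc3Cl)noc2C2CC2)cc1Cl` is the next compound to be tested. It differs from compound 3 in one place: 3-carboxy-1-isopropyl-1H-pyrazol-5-yl in place of 3-carboxyphenyl on a saturated ring carbon. Among the measured compounds shown here, no measured pair shows a change of this kind, so the expected step rests on the change itself. A five-membered ring with two nitrogen atoms and an isopropyl group replacing a plain benzene ring is a sizeable alteration, and a modest rise in the number, somewhat beyond the scatter, is expected. Compound 4 is estimated at 80 nM, with a range of 25 nM to 250 nM, which means an expected step of a 2.4-fold higher number from compound 3 to compound 4 (0.37 log units; beyond the scatter).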

Compound 4, half-maximal effective concentration: 6 nM
The estimate for compound 4 lay 13-fold (1.12 log units) above the measured number; the whole stated range lies above it.
By their numbers in this assay, from the lowest: compound 4; then compounds 3 and 2 (each within the scatter of the next); then compound 1.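

On the saturated ring carbon of the three-membered ring, 3-carboxyphenyl is not required for a low number: 3-carboxy-1-isopropyl-1H-pyrazol-5-yl gives a 5.7-fold lower number from compound 3 to compound 4 (0.75 log units; beyond the scatter) in this single change. The position therefore accepts a five-membered aromatic ring with 2 hetero atoms and an added isopropyl group, with the carboxylic acid kept. No measurement shown here accounts for this step.

From the compounds shown here alone, the ring and the isopropyl group change together, so their separate shares stay open. A methyl group in place of the isopropyl group would begin to divide them.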